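A halogenated benzyl in place of 4-methylbenzyl

The source may hold more compounds than are shown below. What is called first, only, known or untested is meant among the compounds shown, and "the series" means these compounds.

Measured so far:
compound 1 `Cc1ccc(CN2CCC(C(=O)Nc3ccc(CNc4nc(N(C)C)nc5cc(C)ccc45)cc3)CC2)cc1`: > 4150 nM
compound 2 `Cc1ccc2c(NCc3ccc(NC(=O)C4CCN(Cc5ccccc5)CC4)cc3)nc(N3CCN[C@@H](C)C3)nc2c1`: > 8860 nM

In a functional assay on SV5A8 cells (Homo sapiens) for cytotoxicity (on this read-out lower numbers stand for stronger inhibition and higher numbers for weaker inhibition), compound 1 gives > 4150 nM, which is a limit of the assay and not a number (the limit of > 4150 nM in this assay, at which 1 of the 2 values shown sits). Compound 2 likewise gives only a limit, > 8860 nM (the limit of > 8860 nM in this assay, at which 1 of the 2 values shown sits). For the measured compounds named here, with two limits and no measured step, compound 1 cannot be placed above or below compound 2.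

Compound 3 `Cc1ccc2c(NCc3ccc(NC(=O)C4CCN(Cc5ccc(F)cc5Cl)CC4)cc3)nc(N(C)C)nc2c1` differs from compound 1 by 2-chloro-4-fluorophenyl in place of 4-methylphenyl on a saturated chain carbon bound to an amine nitrogen in a ring. Going by the values given here, no step between measured compounds is available, so no change beyond the scatter is expected. Compound 3 is estimated at 8000 nM, within 2000 nM to 30000 nM. The expected step is a step that the limit leaves unreadable from compound 1 to compound 3, most likely reported again as a limit.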

Compound 3, half-maximal inhibitory concentration: > 5910 nM
Compound 3: only a limit was reported; the forecaster's own chance of this, stated with the estimate: 70%; the middle value is on the limit's open side.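

Compound 1 and compound 3 each give only a limit, not a number, so the step between them cannot be read. The compounds shown leave open whether 2-chloro-4-fluorobenzyl in place of 4-methylbenzyl changes cytotoxicity at all.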